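A few compounds are considered here, and "the series" means these few. Any claim that something is new, unique, unknown or untested is made for them only; others in the source may bear on it.

Among the compounds with values here, compound 2 `CCc1ccc(NC2=CC(=O)c3c(nc4n3[C@H]3OC[C@@H](O)[C@H]3OC4)C2=O)cc1` in a functional assay on MCF7 cells (Homo sapiens) for inhibition, read by sulforhodamine B assay (on this read-out higher numbers stand for weaker inhibition and lower numbers for stronger inhibition), gives 8990 nM, the only numerical value among the three measured members. Compound 1 `O=C1C=C(NCc2ccccc2)C(=O)c2c1nc1n2[C@H]2OC[C@@H](O)[C@H]2OC1` in this assay returns a limit of the assay, > 8000 nM. Compound 3 `CCOc1ccccc1NC1=CC(=O)c2nc3n(c2C1=O)[C@H]1OC[C@@H](O)[C@H]1OC3` in this assay likewise returns only a limit, > 4000 nM. Within the data shown here, the single one-point step measured so far, a step that the two limits leave unreadable from compound 1 to compound 3, cannot be sized, since both ends sit at limits (the limit of > 4000 nM in this assay, at which 1 of the 3 values shown sits, (the limit of > 8000 nM in this assay, at which 1 of the 3 values shown sits)); whether 2-ethoxyphenyl in place of benzyl on an amine nitrogen changes inhibition at all is left open.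

Compound 4 `O=C1C(Nc2cccc(F)c2)=CC(=O)c2c1nc1n2[C@H]2OC[C@@H](O)[C@H]2OC1` differs from compound 2 by 3-fluorophenyl in place of 4-ethylphenyl on an amine nitrogen. Among the measured compounds shown here, no measured step touches either the 4-ethylphenyl or the 3-fluorophenyl group, and the one step available is unreadable, so nothing points to a direction for this change. The expectation rests on compound 2 alone and its value of 8990 nM. The expected step is a 1.0-fold higher number from compound 2 to compound 4 (0.00 log units; within the scatter), which is expected to stay within the usual scatter. Compound 4 in this assay is therefore estimated at 9000 nM, with a range from 3000 nM to 30000 nM, and a real chance that only a limit is reported.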

Compound 4, half-maximal inhibitory concentration: > 4000 nM
Compound 4: no number, only a limit; the forecaster's own chance of this, stated with the estimate: 40%; the middle value lies beyond the limit too.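

In this assay, within the data shown here, compound 4 returns > 4000 nM, a limit of the assay and not a number, so no step from compound 2 to compound 4 can be read. Among these compounds, whether 3-fluorophenyl in place of 4-ethylphenyl on an amine nitrogen changes inhibition at all stays open, and compound 2 remains the only member with a numerical value.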